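A few compounds are considered here, and "the series" means these few. Any claim that something is new, unique, unknown or untested is made for them only; others in the source may bear on it.

Compound 1, `CO[C@@H]1C/C=C(\C)C(=O)N(C)[C@@H](C(C)C)C(=O)N[C@H](Cc2cc(Cl)c(O)c(Cl)c2)C(=O)N[C@@H](C(C)C)C(=O)O[C@H](c2ccccc2)[C@H](C)/C=C/C=C/1C`: 21.6 nM
Compound 2, `CO[C@@H]1C/C=C(\C)C(=O)N(C)[C@@H](C(C)C)C(=O)N[C@H](Cc2ccc(O)cc2)C(=O)N[C@@H](C(C)C)C(=O)O[C@H](c2ccccc2)[C@H](C)/C=C/C=C/1C`: 35.9 nM

Within the data shown here, in a functional assay on A549 cells (Homo sapiens) for antiproliferative activity, read by MTT assay, with a stated time of 72 h (on this read-out lower numbers stand for stronger inhibition and higher numbers for weaker inhibition), compound 2 gives 35.9 nM; the only measured step, a 1.7-fold higher number from compound 1 to compound 2 (0.22 log units; within the scatter), lies within the scatter, so compound 2 is not separated from compound 1. Compound 3, `COc1cc(C[C@H]2NC(=O)[C@H](C(C)C)N(C)C(=O)/C(C)=C/C[C@@H](OC)/C(C)=C/C=C/[C@@H](C)[C@@H](c3ccccc3)OC(=O)[C@H](C(C)C)NC2=O)ccc1O`, differs from compound 2 by methoxy in place of hydrogen on an aromatic carbon. Among the measured compounds shown here, no measured step concerns a methoxy group; the single step available, a 1.7-fold higher number from compound 1 to compound 2 (0.22 log units; within the scatter), changes the same aromatic ring elsewhere and stayed within the scatter. From compound 2 to compound 3 a step of a 1.1-fold higher number from compound 2 to compound 3 (0.05 log units; within the scatter) is therefore expected, nothing beyond the scatter. For compound 3 the estimate is 40 nM, with a range from 15 nM to 120 nM.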

Compound 3, half-maximal inhibitory concentration: 20.2 nM
The estimate for compound 3 lay 2.0-fold (0.30 log units) above the measured number, and the stated range covers the measured number.
By their numbers in this assay, from the lowest: compounds 3, 1 and 2 (each within the scatter of the next).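

Among these compounds, the methoxy group, ortho to a hydroxy group, is the first change at this ring position that adds heavy atoms to the 4-hydroxyphenyl of compound 2, and in this assay it gives a 1.8-fold lower number from compound 2 to compound 3 (0.25 log units; within the scatter). Against the dichloro ring of compound 1, the 4-hydroxy-3-methoxyphenyl ring gives a 1.1-fold lower number from compound 1 to compound 3 (0.03 log units; within the scatter), so all three rings remain unseparated. On these data alone, what an amine or an ethoxy group on this aromatic carbon would give remains open, as does the effect of a methoxy group on both carbons flanking the hydroxy group. Nothing available bears on why these numbers stay so close.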